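Swapping bromo for nitro: an expected value

A few compounds are considered here, and "the series" means these few. Any claim that something is new, unique, unknown or untested is made for them only; others in the source may bear on it.

Measured so far in a functional assay on SGC-7901 cells (Homo sapiens) for cytotoxicity, read by MTT assay, with a stated time of 48 h (on this read-out higher numbers stand for weaker inhibition and lower numbers for stronger inhibition), are two compounds
compound 1 `O=C(CSc1ccc(Br)cc1)N1N=C(c2cc3ccccc3oc2=O)C[C@@H]1c1ccccc1` gives 14300 nM
compound 2 `O=C(CSc1ccc(Br)cc1)N1N=C(c2cc3ccccc3oc2=O)C[C@@H]1c1ccc(C(F)(F)F)cc1` gives 12100 nM

Compound 2 lies within the scatter of compound 1, so the two cannot be ranked. Compound 3 `O=C(CSc1ccc([N+](=O)[O-])cc1)N1N=C(c2cc3ccccc3oc2=O)C[C@@H]1c1ccc(C(F)(F)F)cc1` has nitro in place of bromo on an aromatic carbon, para to a large group nitro in place of bromo on an aromatic carbon and is otherwise the same as compound 2. Within the data shown here, only one step has been measured, a 1.2-fold lower number from compound 1 to compound 2 (0.07 log units; within the scatter) and it comes from trifluoromethyl in place of hydrogen at a different place, so it does not test this swap directly. With no measured guide to the swap, no step beyond the scatter is expected in this assay and the uncertainty stays wide. The expected change is a 1.1-fold lower number from compound 2 to compound 3 (0.04 log units; within the scatter) as an estimate. Starting from compound 2, the estimate for compound 3 is 11000 nM (expected range 4000 nM to 26000 nM).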

Compound 3, half-maximal inhibitory concentration: 8510 nM
Compound 3: the middle estimate sits 1.3-fold (0.11 log units) above what was measured, within the range that was stated.
By their numbers in this assay, from the lowest: compounds 3, 2 and 1 (each within the scatter of the next).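

Among these compounds, the earlier compounds all carried bromo on this ring, so this is the first look at what a change here does. In this assay, nitro in place of bromo gives a 1.4-fold lower number from compound 2 to compound 3 (0.15 log units; within the scatter), so compound 2 and compound 3 cannot be ranked. At this aromatic carbon, para to a large group, a single bromine atom can thus give way to three heavy atoms, including two hydrogen-bond acceptors, without a step that stands clear of the scatter. No measurement is at hand that bears on why the swap leaves the number within the scatter.

On these data alone, what an amine or a carboxylic acid at this same carbon would give remains open. So does whether nitro in place of bromo gives a similar step on the core of compound 1, which lacks the trifluoromethyl group.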